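Phenyl for Thiophenyl in a Nitrile Pyridone Series

The source may report more compounds than this note shows. Statements on the series, on what has been measured and on what is new or still open speak of the compounds shown alone.

Measured compounds:
compound 1 `CC1CCCc2c1nc(N)c(C#N)c2-c1cccn1C` — > 100000 nM
compound 2 `Cn1cccc1-c1cc(-c2cccs2)[nH]c(=O)c1C#N` — > 100000 nM
compound 3 `Cn1cccc1-c1cc(-c2ccccc2)nc(N)c1C#N` — 79400 nM

Of the compounds shown here, three have been tested in a functional assay on SF-268 cells (Homo sapiens) for inhibition, read by sulforhodamine B assay, with a stated time of 48 h; a lower number here means a stronger inhibitor of growth, a higher number a weaker inhibitor of growth. For compound 1 the result is a limit of the assay, > 100000 nM. Compound 2 likewise reaches only a limit, > 100000 nM. Compound 3 alone gives a number, 79400 nM. Among the compounds with values here, compound 2 therefore stands at the limit of > 100000 nM in this assay, at which 2 of the 3 values shown sit, with no measured step leading to or from it.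

Compound 4 `Cn1cccc1-c1cc(-c2ccccc2)[nH]c(=O)c1C#N` is not yet measured. It differs from compound 2 in one place: phenyl in place of thiophen-2-yl on an aromatic carbon. Within the data shown here, no step between measured compounds accompanies this change, so its size is open. Compound 3, carrying the same phenyl group on an amino-bearing core, gives 79400 nM, which leaves little room for strong inhibition. Compound 4 is therefore expected to remain weak, with a step of a number no higher from compound 2 to compound 4 (the limit leaves the size open) that is expected to lie within the scatter or to stay at the limit. Compound 4 is estimated at 100000 nM, with a range from 40000 nM to 300000 nM.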

Compound 4, concentration for 50% growth inhibition: > 100000 nM
Compound 4: no number, only a limit; the forecaster's own chance of this, stated with the estimate: 60%; the middle value sits exactly at the limit.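

Within the data shown here, compound 2 and compound 4 each reach only a limit in this assay, so no step between them can be read. The compounds shown leave open whether phenyl in place of thiophen-2-yl changes growth inhibition at all, and compound 2 still stands at the limit: the limit of > 100000 nM in this assay, at which 3 of the 4 values shown sit.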